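This account rests on a few compounds, and the source may have more. Where it says the series, first, only, none or still open, it means among the compounds named here.

In a functional assay on Caco-2 cells (Homo sapiens) for antiproliferative activity, read by MTT assay, with a stated time of 48 h (on this read-out higher numbers stand for weaker inhibition and lower numbers for stronger inhibition), compound 1 `CCn1c(C(=O)NCC#N)ccc1C(CC)(CC)c1ccc(OCCC(O)(CC)CC)c(C)c1` gives > 50000 nM, which is a limit of the assay rather than a number. Compound 2 `CCn1c(C(=O)NCCN)ccc1C(CC)(CC)c1ccc(OCCC(O)(CC)CC)c(C)c1` gives 1740 nM. That step is an at least 28-fold lower number from compound 1 to compound 2 (1.45 log units; beyond the scatter). Compound 3 `CCC(C)C(NC(=O)c1ccc(C(CC)(CC)c2ccc(OCCC(O)(CC)CC)c(C)c2)n1CC)C(=O)OC` gives > 50000 nM, again a limit. Compound 3 thus stands at the limit of > 50000 nM in this assay, at which 2 of the 3 values shown sit, and the return step is an at least 28-fold higher number from compound 2 to compound 3 (1.45 log units; beyond the scatter). Compound 4 `CCn1c(C(=O)NC(CO)CCO)ccc1C(CC)(CC)c1ccc(OCCC(O)(CC)CC)c(C)c1` differs from compound 3 by a group of 6 heavy atoms (4 carbon, 2 oxygen; no ring) in place of a group of 9 heavy atoms (7 carbon, 2 oxygen; no ring), on an amide-type nitrogen. Neither measured step tests this change directly: the only clear gain, an at least 28-fold lower number from compound 1 to compound 2 (1.45 log units; beyond the scatter), came with an aminomethyl, which compound 4 lacks. Because compound 3 sits at the limit of > 50000 nM in this assay, at which 2 of the 3 values shown sit, the step of an at least 2.0-fold lower number from compound 3 to compound 4 (0.30 log units; that floor lies within the scatter) is expected to be unreadable or modest. Compound 4 is therefore expected to give about 25000 nM, between 5000 nM and 50000 nM.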

Compound 4, half-maximal inhibitory concentration: 40200 nM
The estimate for compound 4 lay 1.6-fold (0.21 log units) below the measured number; low and high end bracket the measured number.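

In this assay, the 3-hydroxy-1-(hydroxymethyl)propyl group on the amide-type nitrogen gives a real number rather than a limit, yet it does not match 2-aminoethyl: a 23-fold higher number from compound 2 to compound 4 (1.36 log units; beyond the scatter). The other two steps, an at least 1.2-fold lower number from compound 3 to compound 4 (0.09 log units; that floor lies within the scatter) and an at least 1.2-fold lower number from compound 1 to compound 4 (0.09 log units; that floor lies within the scatter), show no clear gain, since their floors lie within the scatter. Compound 1 and compound 3 carry a limit, not a number: the limit of > 50000 nM in this assay, at which 2 of the 4 values shown sit. On these data alone, whether the amine itself matters stays open: a longer chain ending in an amine, or a carboxylic acid at the end of the chain, would test this.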